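From Cyclohexyl to Cyclohexylmethyl on a Shared Core

This account rests on a few compounds, and the source may have more. Where it says the series, first, only, none or still open, it means among the compounds named here.

Of the compounds shown here, three sharing a core have been measured in a physicochemical assay for lipophilicity, using the shake flask method, measured as octanol-water partition, at pH 7.4; on this read-out higher numbers stand for higher lipophilicity and lower numbers for lower lipophilicity. Compound 1 `NC(=O)c1cnc2ccc(-c3cccnc3)cc2c1NC1CCCC1` gives 3.6, compound 2 `NC(=O)c1cnc2ccc(-c3cccnc3)cc2c1SC1CCCC1` gives 3.2 and compound 3 `NC(=O)c1cnc2ccc(-c3cccnc3)cc2c1NC1CCCCC1` gives 3.8. Compound 3 cannot be told apart from compound 1 on these numbers, and it stands clear only of compound 2.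

Compound 4 `NC(=O)c1cnc2ccc(-c3cccnc3)cc2c1NCC1CCCCC1` has not yet been measured. It differs from compound 3 by a single change: cyclohexylmethyl in place of cyclohexyl on a nitrogen on an aromatic ring.

The closest guide is a change of group at that same nitrogen, cyclohexyl in place of cyclopentyl, which gave a number 0.20 log units higher from compound 1 to compound 3 (within the scatter). The steps of a number 0.40 log units lower from compound 1 to compound 2 (beyond the scatter) and a number 0.60 log units higher from compound 2 to compound 3 (beyond the scatter) are larger, but both involve cyclopentylsulfanyl, which compound 4 does not carry, so they say little here. Among the measured compounds shown here, no measured step introduces cyclohexylmethyl itself, so the guide is indirect.

A similarly small upward step is therefore expected, an estimated a number 0.30 log units higher from compound 3 to compound 4 (within the scatter) in this assay. For compound 4 the estimate is 4.1, with an expected range of 3.7 to 4.5.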

Compound 4, distribution coefficient: > 4.3
Compound 4: a limit, no number (the forecaster's own chance of this, stated with the estimate: 3%); middle value at least 0.20 log units away from the limit.
By their numbers in this assay, from the lowest: compound 2; then compounds 1 and 3 (each within the scatter of the next). At a limit, above all of these: compound 4.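

In this assay compound 4 gives a limit of the assay, not a number: the limit of > 4.3 in this assay, at which 1 of the 4 values shown sits. At this nitrogen the earlier change of ring size gave only a number 0.20 log units higher from compound 1 to compound 3 (within the scatter), whereas inserting the methylene of cyclohexylmethyl gives a number at least 0.50 log units higher from compound 3 to compound 4 (beyond the scatter), so a change at this position can move the read-out beyond the scatter. As far as these compounds go, the wider comparisons, a number at least 0.70 log units higher from compound 1 to compound 4 (beyond the scatter) and a number at least 1.10 log units higher from compound 2 to compound 4 (beyond the scatter), place compound 4 clear of all three earlier compounds, though the full size of each step stays unknown.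

From the compounds shown here alone, how far compound 4 lies past its limit remains open. Also open, going by these compounds, is whether a longer chain on that nitrogen, such as cyclohexylethyl, or a cyclohexyl ring carrying a hydroxyl group would extend this rise or reverse it.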